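Diethylamino to 2-fluoroethoxy: working notes on compound 4

The source may hold more compounds than are shown below. What is called first, only, known or untested is meant among the compounds shown, and "the series" means these compounds.

In a functional assay on SW620/5-FU cells (Homo sapiens) for cytotoxicity, read by MTT assay, with a stated time of 48 h, in the presence of a further agent that is not named here (a higher number here means that more compound is needed for the effect, a lower number that less compound is needed), compound 1 (`Cc1c(Cc2ccccc2)c(NNC(=O)Nc2cc(Cl)nc(Cl)c2)nc2c1cnn2C`) gives 21400 nM and compound 2 (`Cn1ncc2c(-c3ccc(F)cc3)cc(NNC(=O)Nc3cc(Cl)cc(Cl)c3)nc21`) gives 54300 nM. Compound 3 (`CCN(CC)c1cc(NC(=O)NNc2cc(-c3ccc(F)cc3)c3cnn(C)c3n2)cc(Cl)n1`) gives 37000 nM, the second highest of the three numbers, though within the scatter of both compound 2 and compound 1.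

Compound 4 (`Cn1ncc2c(-c3ccc(F)cc3)cc(NNC(=O)Nc3cc(Cl)nc(OCCF)c3)nc21`) differs from compound 3 at one place, with 2-fluoroethoxy in place of diethylamino on an aromatic carbon. That carbon sits on a six-membered aromatic ring with 1 nitrogen, next to the ring nitrogen and meta to a chloro group.

Among the measured compounds shown here, no measured pair isolates a single change, so there is no direct precedent for this one. The expectation rests on compound 3 at 37000 nM as the nearest reference, and no step beyond the scatter is expected in this assay. The expected step is a 1.1-fold lower number from compound 3 to compound 4 (0.05 log units; within the scatter). For compound 4 the estimated value is 33000 nM, with an expected range of 14000 nM to 75000 nM.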

Compound 4, half-maximal effective concentration: 29300 nM
The estimate for compound 4 lay 1.1-fold (0.05 log units) above the measured number, within the range that was stated.
By their numbers in this assay, from the lowest: compounds 1, 4, 3 and 2 (each within the scatter of the next, the first and the last beyond it).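

In this assay, 2-fluoroethoxy in place of diethylamino on the aromatic carbon next to the ring nitrogen gives a 1.3-fold lower number from compound 3 to compound 4 (0.10 log units; within the scatter) and so produces no readable shift, even though the two groups differ in their linking atom. The other single-place comparison, 2-chloro-6-(2-fluoroethoxy)pyridin-4-yl in place of 3,5-dichlorophenyl on an amide-type nitrogen, gives a 1.9-fold lower number from compound 2 to compound 4 (0.27 log units; within the scatter) and also stays inside the usual spread of repeat measurements. Nothing available here bears on why either exchange leaves the number within that spread. Going by these compounds, whether a primary amine, a carboxylic acid or a longer alkoxy chain on this same carbon would move the number beyond the scatter remains open. Also open, on these data alone, is what the fluorine of 2-fluoroethoxy contributes compared with a plain ethoxy group.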